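The compounds below may be only part of what the source reports. "The series", "measured", "known", "first", "only" and "open" are said of these compounds alone.

Measured so far:
- compound 1, `O=C(NCCCCc1ccccc1)c1cccc(C2SCC(=O)N2c2cccc(-c3c[nH]nn3)c2)c1`: 20000 nM
- compound 2, `COc1ccccc1N1C(=O)CSC1c1cc(F)cc(C(=O)NCCCCc2ccccc2)c1`: 10000 nM

Both compounds were tested in a physicochemical assay for solubility, read by turbidimetry, measured as kinetic solubility, at pH 6.8; a higher number here means a more soluble compound, a lower number a less soluble compound. Compound 1 gives 20000 nM and compound 2 gives 10000 nM; these two numbers lie within the usual scatter of each other, so neither compound can be called the more soluble one on this evidence, and compound 1 simply has the larger of the two readings.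

The new compound 3, `COc1ccc(F)cc1N1C(=O)CSC1c1cccc(C(=O)NCCCCc2ccccc2)c1`, has not yet been measured. It differs from compound 1 in one place: a group of 9 heavy atoms (7 carbon, 1 oxygen, 1 fluorine; one six-membered aromatic ring of carbon only) in place of a group of 11 heavy atoms (8 carbon, 3 nitrogen; one five-membered aromatic ring with 3 hetero atoms, one six-membered aromatic ring of carbon only), on an amide-type nitrogen in a ring. The group that leaves carries a five-membered aromatic ring with 3 hetero atoms and 1 hydrogen-bond donor, while the entering 5-fluoro-2-methoxyphenyl has 0 hydrogen-bond donors. The entering group is close to what compound 2 carries on its ring nitrogen, and compound 2 gives 10000 nM in this assay.

Among the measured compounds shown here, no measured step covers exactly this change. A small downward move is expected, not clearly beyond the scatter. The expected step of a 2.0-fold lower number from compound 1 to compound 3 (0.30 log units; within the scatter) is a modest decrease. Compound 3 is estimated at 10000 nM, with a likely range from 4000 nM to 25000 nM.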

Compound 3, solubility: 10000 nM
Compound 3: the middle estimate sits on the measured number at the digits printed; the range from low to high includes it.
By their numbers in this assay, from the lowest: compounds 2, 3 and 1 (each within the scatter of the next).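

At the amide-type nitrogen in the ring, 5-fluoro-2-methoxyphenyl takes the place of a six-membered carbon aromatic ring carrying a five-membered aromatic ring with 3 hetero atoms, and this gives a 2.0-fold lower number from compound 1 to compound 3 (0.30 log units; within the scatter) in this assay. Among the compounds shown here, compounds 1 and 3 form the first pair here that differs in one place, so this is the first direct reading of this position, and the step lies within the scatter: the two compounds cannot be told apart, even though the swap removes the five-membered ring and the hydrogen-bond donor it carries. No measurement given here bears on this result.

From the compounds shown here alone, what stays open is whether any group on this nitrogen can move the reading beyond the scatter, since a single swap at one position says little about others, such as a ring carrying an amine or a carboxylic acid. The compounds shown also leave open whether this same swap would read alike with a longer or shorter chain on the amide of the shared core.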